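Replacing a fused aromatic ring with cyclopropyl

This account rests on a few compounds, and the source may have more. Where it says the series, first, only, none or still open, it means among the compounds named here.

Compound 1 `CCOC(=O)c1cnc(-c2cccc([N+](=O)[O-])c2)nc1NN1C(=O)C=C(C)C1=O`: 7000 nM
Compound 2 `CCOC(=O)c1cnc(-c2cc3ccccc3s2)nc1NN1C(=O)C=C(C)C1=O`: 4000 nM

In a functional assay on Jurkat cells for inhibition of nuclear factor NF-kappa-B complex (Homo sapiens) (on this read-out higher numbers stand for weaker inhibition and lower numbers for stronger inhibition), compound 2 stands at 4000 nM and compound 1 at 7000 nM; the step of a 1.8-fold lower number from compound 1 to compound 2 (0.24 log units; within the scatter) lies within the scatter, so the two cannot be told apart. Compound 3 `CCOC(=O)c1cnc(C2CC2)nc1NN1C(=O)C=C(C)C1=O` carries the change (cyclopropyl in place of 1-benzothiophen-2-yl on an aromatic carbon). Going by the values given here, the only measured step swaps one aromatic group for another and stays within the scatter; no step trades an aromatic ring for a small saturated ring, so it offers little guidance. A weaker result is expected, a step of a 3.0-fold higher number from compound 2 to compound 3 (0.48 log units; beyond the scatter). The estimate for compound 3 is 12000 nM, between 4000 nM and 40000 nM.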

Compound 3, half-maximal inhibitory concentration: 1000 nM
Beside the measured number, compound 3's estimate is 12-fold (1.08 log units) above it; the measured number lies below the stated range.
By their numbers in this assay, from the lowest: compound 3; then compounds 2 and 1 (each within the scatter of the next).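

At this position, on an aromatic carbon between two ring nitrogen atoms, this assay gives a 4.0-fold lower number from compound 2 to compound 3 (0.60 log units; beyond the scatter) and a 7.0-fold lower number from compound 1 to compound 3 (0.85 log units; beyond the scatter) when the aromatic group gives way to cyclopropyl. Among these three compounds, then, an aromatic group at this position is not needed for the lowest number, and the small saturated ring gives a step beyond the scatter from both aromatic groups. Nothing available explains this gain.

As far as these compounds go, how an isopropyl group, a cyclobutyl ring or an amine would fare at this position remains open. So does whether the gain would hold with a carboxylic acid in place of the ethoxycarbonyl group.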